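Isoflavone series: chain terminus and aldehyde dehydrogenase inhibition

A few compounds are considered here, and "the series" means these few. Any claim that something is new, unique, unknown or untested is made for them only; others in the source may bear on it.

Measured compounds:
compound 1 `O=c1c(-c2ccc(O)cc2)coc2cc(OCCCBr)ccc12`, 260 nM
compound 2 `O=C(O)CCCCCCCCCOc1ccc2c(=O)c(-c3ccc(O)cc3)coc2c1`, 4 nM

Compound 2 holds the lowest number of the two in an assay on isolated protein (Cricetulus griseus) for inhibition of aldehyde dehydrogenase, mitochondrial (Homo sapiens); a higher number here means a weaker inhibitor, a lower number a stronger inhibitor; the nearest measured compound is compound 1, which stands well above it, since a 65-fold lower number from compound 1 to compound 2 (1.81 log units; beyond the scatter). Compound 3 `O=c1c(-c2ccc(O)cc2)coc2cc(OCCCCBr)ccc12` is not yet measured in this assay. It differs from compound 2 as follows: bromo in place of 5-carboxypentyl on a saturated chain carbon, four bonds along the chain from an oxygen on an aromatic ring. Going by the values given here, the one measured step that bears on this change is the step from compound 1 to compound 2, in which the same kind of exchange, run the other way, gave a large drop in the number. Compound 3 is expected to reverse that movement, so the estimated change is a 55-fold higher number from compound 2 to compound 3 (1.74 log units; beyond the scatter), a large rise beyond the scatter. Compound 3 also resembles compound 1, differing from it only by one added chain carbon, so its number is expected to land near that of compound 1. The estimate for compound 3 in this assay is 220 nM, with a range from 70 nM to 700 nM.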

Compound 3, half-maximal inhibitory concentration: 270 nM
Beside the measured number, compound 3's estimate is 1.2-fold (0.09 log units) below it, and the stated range covers the measured number.
By their numbers in this assay, from the lowest: compound 2; then compounds 1 and 3 (each within the scatter of the next).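

In this assay, the bromo-ended chain accepts bromomethyl in place of bromo with a 1.0-fold higher number from compound 1 to compound 3 (0.02 log units; within the scatter), so this one added chain carbon leaves the two bromo compounds indistinguishable. The exchange of 5-carboxypentyl for bromo, four bonds along the chain from an oxygen on an aromatic ring, gives a 68-fold higher number from compound 2 to compound 3 (1.83 log units; beyond the scatter), so the large gap to compound 2 now stands against a second bromo compound and not against compound 1 alone. No evidence is available to explain the size of this exchange.

Compound 2 differs from both bromo compounds in chain length and in its carboxylic acid end, so the compounds shown do not separate these two changes. A longer chain ending in bromo, or a short chain ending in a carboxylic acid, would tell them apart.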